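The source may hold more compounds than are shown below. What is called first, only, known or untested is meant among the compounds shown, and "the series" means these compounds.

Compound 3 `Cc1ccc(NC(=O)NC(=O)c2ccc(OCc3cccc(Cl)c3)cc2)cc1-c1nc2ccccc2[nH]1` stands at the lowest of the three measured numbers in a functional assay on MNK45 cells (Homo sapiens) for inhibition, read by MTT assay, with a stated time of 48 h (a higher number here means a weaker inhibitor, a lower number a stronger inhibitor), where compound 3 gives 28000 nM. Compound 2 `Cc1ccc(NC(=O)NC(=O)c2ccc(OCc3ccccc3)cc2)cc1-c1nc2ccccc2[nH]1` gives 35100 nM in this assay, a gap within the scatter, while compound 1 `Cc1ccc(NC(=S)NC(=O)c2ccc(OCc3ccccc3)cc2)cc1-c1nc2ccccc2[nH]1` gives 57800 nM, a gap beyond it. Among the measured compounds shown here, the only single-place step among the measured compounds, a 1.3-fold lower number from compound 2 to compound 3 (0.10 log units; within the scatter), is small. Compound 4 `Cc1ccc(NC(=O)NC(=O)c2ccc(OCc3ccc(C(F)(F)F)cc3)cc2)cc1-c1nc2ccccc2[nH]1` differs from compound 3 by 4-(trifluoromethyl)phenyl in place of 3-chlorophenyl on a saturated chain carbon bound to an oxygen on an aromatic ring. For the measured compounds named here, no measured step exchanges one substituted benzyl for another, so the expectation rests only on that small earlier step, and a step of a 1.1-fold lower number from compound 3 to compound 4 (0.03 log units; within the scatter) is expected, none beyond the scatter. Compound 4 is therefore estimated at 26000 nM in this assay, within a range of 10000 nM to 65000 nM.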

Compound 4, half-maximal inhibitory concentration: 16800 nM
Beside the measured number, compound 4's estimate is 1.5-fold (0.19 log units) above it; low and high end bracket the measured number.
By their numbers in this assay, from the lowest: compounds 4, 3, 2 and 1 (each within the scatter of the next, the first and the last beyond it).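

On the benzyl ring reached through the oxygen, trifluoromethyl in place of hydrogen gives a 2.1-fold lower number from compound 2 to compound 4 (0.32 log units; beyond the scatter) in this assay, the first single-place change there to pass the scatter, though only modestly. Exchanging 3-chlorophenyl for 4-(trifluoromethyl)phenyl gives a 1.7-fold lower number from compound 3 to compound 4 (0.22 log units; within the scatter), so these two substituted rings are not told apart. No measurement at hand bears on the cause of either step. The compounds shown leave open how an amine or a carboxylic acid on that ring would read, and whether a longer chain in place of the benzyl link would change the number.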